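The source may hold more compounds than are shown below. What is called first, only, known or untested is meant among the compounds shown, and "the series" means these compounds.

Working notes on the series.

Measured compounds in a functional assay on M14 cells (Homo sapiens) for inhibition, read by sulforhodamine B assay, with a stated time of 48 h, tested at 10 uM; on this read-out lower numbers stand for less inhibition and higher numbers for more inhibition at the one concentration tested (going by the name of the read-out):
- compound 1, `COc1ccc(-c2cn3ccnc3c(-c3ccc4ncn(C5CCCCC5)c4c3)n2)cc1`: 89.2%
- compound 2, `Fc1ccc(-c2cn3ccnc3c(-c3ccc4ncn(C5CCCCC5)c4c3)n2)cc1`: 2.98%
- compound 3, `COc1ccccc1-c1cn2ccnc2c(-c2ccc3ncn(C4CCCCC4)c3c2)n1`: 1.12%

Compound 1 is the only one of the three with a high number in this assay. Compound 2 differs from it by fluoro in place of methoxy on an aromatic carbon, and the step is a number 86.2 percentage points lower from compound 1 to compound 2 (beyond the scatter). Compound 3 differs from compound 1 by 2-methoxyphenyl in place of 4-methoxyphenyl on an aromatic carbon, and that step is a number 88.1 percentage points lower from compound 1 to compound 3 (beyond the scatter). Between compound 2 and compound 3 the step is a number 1.9 percentage points lower from compound 2 to compound 3 (within the scatter), so these two cannot be ordered.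

Not yet measured is compound 4, `Fc1ccccc1-c1cn2ccnc2c(-c2ccc3ncn(C4CCCCC4)c3c2)n1`. It differs from compound 3 by fluoro in place of methoxy on an aromatic carbon. This is the same kind of change as that from compound 1 to compound 2, where the place reads para to a large group, while here it reads ortho to a large group; it is therefore the same kind of change, not the same. The earlier step of this kind was a number 86.2 percentage points lower from compound 1 to compound 2 (beyond the scatter), but compound 3 already stands at the lowest number in the set, so a step of comparable size downward is not possible from 1.12%. The expected step in this assay is a number 1.9 percentage points higher from compound 3 to compound 4 (within the scatter), resting on compound 3 at 1.12% and on compound 2 at 2.98%, both low. For compound 4 the estimate in this assay is 3%, expected to lie between 0% and 15%.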

Compound 4, a percentage reported as inhibition, at one concentration (the size of the read-out at that concentration, not a potency): 2.92%
Estimate against measurement, compound 4: 0.1 percentage points above; measured number inside the range.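

In this assay, fluoro in place of methoxy on an aromatic carbon does not give the same result on the two cores, the one carrying 4-methoxyphenyl and the one carrying 2-methoxyphenyl: the same change on two cores in this assay, a number 86.2 percentage points lower (beyond the scatter) from compound 1 to compound 2 and a number 1.8 percentage points higher (within the scatter) from compound 3 to compound 4, 88 percentage points apart, beyond the scatter of two such steps. The second step, a number 1.8 percentage points higher from compound 3 to compound 4 (within the scatter), starts from a low number with little room beneath it, so the pair shows that the large drop seen with 4-methoxyphenyl cannot be carried over as a fixed step, but it does not show why the two cases part, and two pairs support no rule for this change. The low level also holds across the fluoro pair, a number 0.1 percentage points lower from compound 2 to compound 4 (within the scatter), so the 2-fluorophenyl and 4-fluorophenyl compounds cannot be ordered, while a number 86.3 percentage points lower from compound 1 to compound 4 (beyond the scatter), which leaves 4-methoxyphenyl as the only one of the four aryl groups shown with a high number.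

Still open, going by these compounds, is whether the high number belongs to methoxy alone or would remain with a 4-ethoxyphenyl, 4-hydroxyphenyl or 4-dimethylaminophenyl group in its place. Also open, on these data alone, is whether it would survive exchanging cyclohexyl for an isopropyl group or a piperidine ring.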